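The source may hold more compounds than are shown below. What is called first, only, known or untested is meant among the compounds shown, and "the series" means these compounds.

Among the measured compounds shown here, in a functional assay on MCF7 cells (Homo sapiens) for cytotoxicity, read by MTT assay, with a stated time of 72 h (on this read-out higher numbers stand for lower toxicity in this test and lower numbers for higher toxicity in this test), compound 1 (`Nc1cc(C(F)(F)F)cc2c1SSSSS2`) gives 14000 nM and compound 2 (`O=C(CN1CCCCC1)Nc1cc(C(F)(F)F)cc2c1SSSSS2`) gives 19300 nM as the only other measured value. Compound 2 therefore stands within the usual scatter of compound 1. Compound 3 (`CCCCN(CCCC)CC(=O)Nc1cc(C(F)(F)F)cc2c1SSSSS2`) departs from compound 2 by dibutylamino in place of piperidin-1-yl on a saturated chain carbon bound to a carbonyl carbon and thus has dibutylamino in place of piperidin-1-yl on a saturated chain carbon bound to a carbonyl carbon. For the measured compounds named here, no measured pair shows this change, and the expected 1.4-fold lower number from compound 2 to compound 3 (0.14 log units; within the scatter) in this assay stays within the scatter, with no direction beyond it. Compound 3 is estimated at 14000 nM with 6000 nM to 30000 nM as its expected range.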

Compound 3, half-maximal cytotoxic concentration: 28100 nM
Compound 3: middle estimate off by 2.0-fold (0.30 log units), on the low side; the range from low to high includes it.
By their numbers in this assay, from the lowest: compounds 1, 2 and 3 (each within the scatter of the next).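

In this assay the swap of piperidin-1-yl for dibutylamino on a saturated chain carbon bound to a carbonyl carbon gives a 1.5-fold higher number from compound 2 to compound 3 (0.16 log units; within the scatter) and so stays within the scatter. Among the compounds shown here, at this place, then, the open dibutylamino group reads like the ring it replaces, a comparison the earlier compounds could not offer. Nothing measured here explains this result. Still open, going by these compounds, is how a morpholine ring, a carboxylic acid or a primary amine would read at this place. On these data alone, whether a longer chain between carbonyl and amine would shift the number also remains open.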